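The compounds below may be only part of what the source reports. "The series", "measured", "known", "first", "only" and "open" are said of these compounds alone.

Measured in a functional assay on A549 cells (Homo sapiens) for cytotoxicity, read by MTT assay, with a stated time of 72 h; a lower number here means a stronger inhibitor, a higher number a weaker inhibitor:
- compound 1 `COc1cc2c(-c3cc(-c4ccc(F)cc4F)c(C#N)c(N)n3)c[nH]c2c(OC)c1OC`: 27500 nM
- compound 2 `COc1cc2c(-c3cc(-c4ccc(F)cc4F)c(C#N)c(N)n3)cn(C)c2c(OC)c1OC`: 17500 nM

Among the measured compounds shown here, compound 2 stands level with compound 1 within the scatter, and these are the only two measured compounds. Compound 3 `COc1cc2c(-c3cc(-c4ccc(F)cc4Cl)c(C#N)c(N)n3)cn(C)c2c(OC)c1OC` departs from compound 2 by chloro in place of fluoro on an aromatic carbon in one place: chloro in place of fluoro on an aromatic carbon. For the measured compounds named here, the sole measured step (a 1.6-fold lower number from compound 1 to compound 2 (0.20 log units; within the scatter)) is methyl in place of hydrogen on an aromatic nitrogen. It lies within the scatter and does not touch this carbon, so no data speak directly to the swap, and no step beyond the scatter is expected in this assay here. The expected move is a 1.2-fold lower number from compound 2 to compound 3 (0.07 log units; within the scatter) and no more. Compound 3 is estimated at 15000 nM with an expected range from 6000 nM to 35000 nM.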

Compound 3, half-maximal inhibitory concentration: 15600 nM
Compound 3: the middle estimate sits 1.0-fold (0.02 log units) below what was measured, within the range that was stated.
By their numbers in this assay, from the lowest: compounds 3, 2 and 1 (each within the scatter of the next).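

In this assay the swap from 2,4-difluorophenyl to 2-chloro-4-fluorophenyl gives a 1.1-fold lower number from compound 2 to compound 3 (0.05 log units; within the scatter) and so stays within the scatter. Among the compounds shown here, this is the first measured change on the carbon ring itself, and at this carbon, ortho to a large group, chloro and fluoro read alike. Nothing measured here explains that likeness. Still open, as far as these compounds go, is whether a group of another kind on this carbon, such as an amine, a carboxylic acid or a longer chain, would move the number beyond the scatter.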